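This account rests on a few compounds, and the source may have more. Where it says the series, first, only, none or still open, it means among the compounds named here.

Measured compounds in a functional assay on SW1573 cells (Homo sapiens) for inhibition, read by sulforhodamine B assay, with a stated time of 48 h; on this read-out lower numbers stand for stronger inhibition of growth and higher numbers for weaker inhibition of growth:

compound 1 `COC(=O)[C@@]1(C)CCC=C2[C@@H]1CC[C@@H](C)[C@]2(C)Cc1c[nH]c2c(Br)cccc12`, 14000 nM
compound 2 `COC(=O)[C@@]1(C)CCC=C2[C@@H]1CC[C@@H](C)[C@]2(C)Cc1c[nH]c2c(Cl)cccc12`, 14000 nM
compound 3 `COC(=O)[C@@]1(C)CCC=C2[C@@H]1CC[C@@H](C)[C@]2(C)Cc1c(C)[nH]c2ccc(Br)cc12`, 14000 nM

Within the data shown here, the one measured step is the change (chloro in place of bromo on an aromatic carbon); it gave no change at the digits printed from compound 1 to compound 2 (within the scatter). Compound 3 shares a core with compound 1 only in part; the difference between the two cores is not broken down here. Compounds 1, 2 and 3 stand level with one another at the digits given, so no order among them can be read.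

Compound 4 `COC(=O)[C@@]1(C)CCC=C2[C@@H]1CC[C@@H](C)[C@]2(C)Cc1c(C)[nH]c2ccc(Cl)cc12` has not yet been measured. It differs from compound 3 by chloro in place of bromo on an aromatic carbon. This is the same kind of change as from compound 1 to compound 2, not the same: there the carbon was ortho to a fused ring and meta to a fused ring, here it is meta to a fused ring and para to a fused ring. Among the measured compounds shown here, the only precedent is the flat step no change at the digits printed from compound 1 to compound 2 (within the scatter), so the expected step for compound 4 is no change at the digits printed from compound 3 to compound 4 (within the scatter), resting on that precedent alone. Compound 4 is therefore estimated at 14000 nM in this assay, with an expected span from 7000 nM to 28000 nM.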

Compound 4, concentration for 50% growth inhibition: 14000 nM
Estimate against measurement, compound 4: no gap at the digits printed, within the range that was stated.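

In this assay, chloro in place of bromo on an aromatic carbon gave no change at the digits printed from compound 3 to compound 4 (within the scatter), and the change carries from one core to the other without a detectable difference: the same change on two cores in this assay, no change at the digits printed (within the scatter) from compound 1 to compound 2 and no change at the digits printed (within the scatter) from compound 3 to compound 4, 1.0-fold (0.00 log units) apart, within the scatter of two such steps. The two steps differ in the place of the halogen as well as in the core, so these two pairs cannot separate the effect of one from the other. Among these compounds, they show only that this exchange was flat on these two cores, not that it would stay flat on a further core or that other groups could replace bromo without a change in growth inhibition.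

The compounds shown carry only bromo or chloro on the aromatic ring, leaving open what hydrogen, a nitrile, an amine or a methoxy group would do there. Going by these compounds, all of them also keep the methyl ester, so the read-out with a carboxylic acid or an amide in its place remains unknown.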